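Swapping the aryl group on a urea in a kidney-cancer cell assay

The source may hold more compounds than are shown below. What is called first, only, known or untested is meant among the compounds shown, and "the series" means these compounds.

Measured compounds and their values:
Compound 1, `COc1cc(Cl)cc(-c2nn(-c3cccc(NC(=O)c4ccc(Cl)c(Cl)c4)c3)cc2-c2ccncc2)c1`: 63.6%
Compound 2, `COc1cc(Cl)cc(-c2nn(-c3cccc(NC(=O)Nc4cc(C(F)(F)F)cc(C(F)(F)F)c4)c3)cc2-c2ccncc2)c1`: 8.99%
Compound 3, `COc1cc(Cl)cc(-c2nn(-c3cccc(NC(=O)Nc4ccc(Cl)c(Cl)c4)c3)cc2-c2ccncc2)c1`: 7.49%

In a functional assay on CAKI-1 cells (Homo sapiens) for inhibition, read by sulforhodamine B assay, with a stated time of 48 h, tested at 10 uM (a higher number here means a weaker effect of the compound at the concentration tested, a lower number a stronger effect), compound 3 gives the lowest of the three numbers. Its nearest neighbour is compound 2, whose value lies within the scatter of repeated measurements, so the two cannot be told apart; its furthest is compound 1, which lies beyond the scatter. Within the data shown here, the one step that can be read directly, a number 56.1 percentage points lower from compound 1 to compound 3 (beyond the scatter), turns the link next to the carbonyl from a carbon to a nitrogen and brings a large drop in the number.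

Compound 4, `COc1cc(Cl)cc(-c2nn(-c3cccc(NC(=O)Nc4cccc(C(F)(F)F)c4)c3)cc2-c2ccncc2)c1`, has not yet been measured in this assay. It differs from compound 3 in one place: 3-(trifluoromethyl)phenyl in place of 3,4-dichlorophenyl on an amide-type nitrogen. Among the measured compounds shown here, no measured step changes exactly this group, so the step from compound 1 to compound 3 does not bear on it directly. What the data do show is that compound 2 and compound 3, which carry different aryl groups on the same urea nitrogen, give values within the scatter of each other. On that basis the step of a number 7.5 percentage points higher from compound 3 to compound 4 (within the scatter) is expected to stay small, with the number for compound 4 perhaps drifting a little upward. Compound 4 is therefore estimated at 15%, with a range from 5% to 40%.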

Compound 4, a percentage reported as activity, at one concentration (the size of the read-out at that concentration, not a potency): 16.1%
Compound 4: the middle estimate sits 1.1 percentage points below what was measured; the range from low to high includes it.
By their numbers in this assay, from the lowest: compounds 3, 2 and 4 (each within the scatter of the next); then compound 1.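

In this assay, exchanging 3,4-dichlorophenyl for 3-(trifluoromethyl)phenyl on the urea nitrogen gives a number 8.6 percentage points higher from compound 3 to compound 4 (within the scatter), so this position accepts a second kind of aryl group without a change that can be told from the noise. Putting hydrogen in place of one trifluoromethyl group gives a number 7.1 percentage points higher from compound 2 to compound 4 (within the scatter), so compounds carrying one or two trifluoromethyl groups on this ring cannot be told apart here. The large gain from the urea link is also not tied to the 3,4-dichlorophenyl group: with 3-(trifluoromethyl)phenyl on the urea, the comparison with the amide gives a number 47.5 percentage points lower from compound 1 to compound 4 (beyond the scatter), a second large step in the same direction as the one seen before.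

No measurement available here explains why these aryl groups give such similar numbers. Still open, as far as these compounds go, is whether the urea compounds would hold these low numbers with a plain phenyl ring, or with an amine or a carboxylic acid in place of trifluoromethyl, and a read-out at a single concentration cannot show whether compounds this close differ in potency.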